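A few compounds are considered here, and "the series" means these few. Any claim that something is new, unique, unknown or untested is made for them only; others in the source may bear on it.

Compounds 1, 2 and 3 share one core and differ only in the aryl group on the chain. Compound 1 `COc1ccc(C(=O)/C=C/c2cc(OC)c(OC)c(OC)c2)c2c1C=CC(C)(C)O2` gives, in a functional assay on HepG2 cells (Homo sapiens) for antiproliferative activity, read by MTT assay, with a stated time of 24 h (on this read-out higher numbers stand for weaker inhibition and lower numbers for stronger inhibition), a value of > 10000 nM, which is a limit of the assay rather than a number. Compound 3 `COc1ccc(C(=O)/C=C/c2cccc3ccccc23)c2c1C=CC(C)(C)O2` likewise yields only a limit, > 10000 nM, in this assay. Compound 2 `COc1ccc(/C=C/C(=O)c2ccc(OC)c3c2OC(C)(C)C=C3)c(F)c1` is the one that gives a real number: in this assay compound 2 reaches 7560 nM. It therefore stands alone among the three, the other two sitting at the limit of > 10000 nM in this assay, at which 2 of the 3 values shown sit.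

Compound 4 `COc1ccc(C(=O)/C=C/c2cccs2)c2c1C=CC(C)(C)O2` has not yet been measured in this assay. Its structure differs from that of compound 2 in one place: thiophen-2-yl in place of 2-fluoro-4-methoxyphenyl on a double-bonded chain carbon bound to a double-bonded chain carbon. Going by the values given here, since no pair of measured compounds differs in a single place, no measured step shows what such a swap of the aryl group does to the read-out. Compound 4 is expected to land at roughly 9500 nM, somewhere between 4000 nM and 25000 nM, with a real chance that the assay reports only a limit. The step of a 1.3-fold higher number from compound 2 to compound 4 (0.10 log units; within the scatter) is thus expected to be modest, toward weaker inhibition if anything, and not clearly beyond the scatter.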

Compound 4, half-maximal inhibitory concentration: > 10000 nM
Compound 4: only a limit was reported; the forecaster's own chance of this, stated with the estimate: 50%; at least 1.0-fold (0.02 log units) between middle value and limit.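

In this assay, thiophen-2-yl in place of 2-fluoro-4-methoxyphenyl on a double-bonded chain carbon bound to a double-bonded chain carbon gives the only single-place step shown, an at least 1.3-fold higher number from compound 2 to compound 4 (0.12 log units; that floor lies within the scatter). Compound 4 gives > 10000 nM, which is a limit of the assay and not a number, so the step fixes only a floor: it does not establish that this swap weakens inhibition, and it does not exclude a much larger loss. Compound 2 remains the only compound with a real number, while the others share one limit: the limit of > 10000 nM in this assay, at which 3 of the 4 values shown sit.

How far compound 4 lies past its limit stays open, and the compounds shown do not separate the contributions of the fluoro and methoxy groups within 2-fluoro-4-methoxyphenyl. Also open, on these data alone, is whether an aryl group carrying an amine or a carboxylic acid at this place would give a clearly lower number than compound 2.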